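The compounds below may be only part of what the source reports. "The series", "measured", "known", "first", "only" and "open" are said of these compounds alone.

Measured so far, all in an ADME assay on HEK293 cells (Homo sapiens) for antiproliferative activity, read by MTT assay; on this read-out lower numbers stand for stronger inhibition and higher numbers for weaker inhibition:

Compound 1, `CCNC(=O)c1oc2nc(-c3ccccc3)cc(C(F)(F)F)c2c1N`, gives 70000 nM.
Compound 2, `Nc1c(C(=O)N/N=C/c2ccc(Br)cc2)oc2nc(-c3cccs3)cc(C(F)(F)F)c12`, gives 86000 nM.
Compound 3, `Nc1c(C(=O)NC2CCCC2)oc2nc(-c3ccccc3)cc(C(F)(F)F)c12`, gives 85000 nM.

All three share a common core and differ only in the group attached to the amide. The numbers sit close together: compound 2 has the highest of the three, but its gap to compound 3 is within the scatter, as is its gap to compound 1, so none of the three can be called stronger or weaker than the others. For the measured compounds named here, the one measured step that changes a single place, cyclopentyl in place of ethyl on the amide nitrogen, reads a 1.2-fold higher number from compound 1 to compound 3 (0.08 log units; within the scatter).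

Compound 4, `Cc1ccc(/C=N/NC(=O)c2oc3nc(-c4cccs4)cc(C(F)(F)F)c3c2N)cc1`, is the unmeasured compound. It is compound 2 with one change: methyl in place of bromo on an aromatic carbon.

Going by the values given here, no measured step touches this part of the molecule, so the only guidance is that every change seen so far, including the swap of ethyl for cyclopentyl, has stayed within the scatter in this assay. On that basis compound 4 is expected to give a number close to that of compound 2, with an estimated step of no change at the digits printed from compound 2 to compound 4 (within the scatter), not beyond the scatter in either direction. The estimate for compound 4 in this assay is 86000 nM, in a range from 40000 nM to 180000 nM.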

Compound 4, half-maximal inhibitory concentration: 78000 nM
Beside the measured number, compound 4's estimate is 1.1-fold (0.04 log units) above it; measured number inside the range.
By their numbers in this assay, from the lowest: compounds 1, 4, 3 and 2 (each within the scatter of the next).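

In this assay, for the compounds shown here, the swap of 4-bromophenyl to 4-methylphenyl gives a 1.1-fold lower number from compound 2 to compound 4 (0.04 log units; within the scatter), the first reading of a change on this aromatic ring, as the earlier step changed a group on the amide nitrogen. One heavy atom, a bromine, is exchanged for another, a carbon, at a place para to a large group, and the result stays within the scatter, so this pair shows no measurable response to this particular change. Nothing measured here explains why the two groups read alike.

From the compounds shown here alone, neither group carries a ring, a hydrogen-bond donor, a hydrogen-bond acceptor or a net charge, so it remains open whether an amine, a carboxylic acid or a longer chain such as butyl in the same place would also stay within the scatter. A single pair also cannot tell whether this result holds at other places on the ring or whether the same exchange would read alike on a compound with a different group on the amide nitrogen.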